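This account rests on a few compounds, and the source may have more. Where it says the series, first, only, none or still open, it means among the compounds named here.

Measured so far in a functional assay on GC3/MTK- cells (Homo sapiens) for inhibition; on this read-out lower numbers stand for stronger inhibition and higher numbers for weaker inhibition:
- Compound 1 `C#CCN(Cc1ccc2nc(C)nc(O)c2c1)c1ccccc1`: > 10700 nM, a limit
- Compound 2 `C#CCN(Cc1ccc2nc(C)nc(O)c2c1)c1cccc(CO)c1`: > 54000 nM, a limit

Compound 2 has no exact number in this assay, since its > 54000 nM is a limit of the assay. Compound 1 likewise has only a limit to show. Compound 3 `C#CCN(Cc1ccc2nc(C)nc(O)c2c1)c1cccc(C(C)O)c1` differs from compound 2 by a single change: methyl in place of hydrogen on a saturated chain carbon bound to an aromatic carbon and an oxygen on a saturated carbon. This is methyl in place of hydrogen on a saturated chain carbon bound to an aromatic carbon and an oxygen on a saturated carbon, which turns hydroxymethyl into 1-hydroxyethyl.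

Among the measured compounds shown here, only one measured step bears on this change, the one that brought in the hydroxymethyl group: a step that the two limits leave unreadable from compound 1 to compound 2. Its size cannot be read, so it offers no measure for the added methyl and favours no direction. No change beyond the usual scatter is therefore expected in this assay, and another report of only a limit is quite likely. The expected step is an at least 1.3-fold lower number from compound 2 to compound 3 (0.13 log units; that floor lies within the scatter). For compound 3 the estimated value is 40000 nM, with an expected range from 10000 nM to 120000 nM.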

Compound 3, half-maximal inhibitory concentration: 49000 nM
The estimate for compound 3 lay 1.2-fold (0.09 log units) below the measured number; low and high end bracket the measured number.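

In this assay compound 3 gives 49000 nM, the only exact number among the compounds shown, so the 1-hydroxyethyl group provides the first firm figure for a substituent at this position. Adding methyl on the saturated chain carbon bound to an aromatic carbon and an oxygen gives an at least 1.1-fold lower number from compound 2 to compound 3 (0.04 log units; that floor lies within the scatter); since this is only a floor, the true size of the step remains unfixed, and the result does not show that the methyl changes the number beyond the scatter. The steps that start from compound 1 cannot be read, so the result puts no size on the effect of either oxygen-bearing group against plain hydrogen.

Compound 1 has only a limit, > 10700 nM, which leaves open how the 1-hydroxyethyl group compares with hydrogen in this assay. Going by these compounds, it also remains open whether an amine or a carboxylic acid at this place, or a longer chain in place of the added methyl, would move the number beyond the scatter.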